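Swapping a propyl for a tosylamide on the triazole arm

The source may report more compounds than this note shows. Statements on the series, on what has been measured and on what is new or still open speak of the compounds shown alone.

Of the compounds shown here, three of the shared core have been measured in a functional assay on SW-620 cells (Homo sapiens) for antiproliferative activity, read by MTT assay, with a stated time of 72 h; a lower number here means a stronger inhibitor, a higher number a weaker inhibitor. Compound 1 `Cc1ccc(-c2cn(C/C=C3\OC(=O)C(OCc4ccccc4)=C3OCc3ccccc3)nn2)cc1` gives only a limit of the assay, > 100000 nM. Compound 3 `O=C1O/C(=C\Cn2cc(-c3cc(C(F)(F)F)cc(C(F)(F)F)c3)nn2)C(OCc2ccccc2)=C1OCc1ccccc1` likewise gives a limit, > 100000 nM. Among the measured compounds shown here, compound 2 `CCCCc1cn(C[C@H](O)[C@H]2OC(=O)C(OCc3ccccc3)=C2OCc2ccccc2)nn1` is the one member of the set with a number, giving 47500 nM in this assay. Two of the three values therefore sit at the limit of > 100000 nM in this assay, at which 2 of the 3 values shown sit, and compound 2 stands alone as the sole measured activity.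

Compound 4 `Cc1ccc(S(=O)(=O)NCc2cn(C[C@H](O)[C@H]3OC(=O)C(OCc4ccccc4)=C3OCc3ccccc3)nn2)cc1` has not yet been measured. It differs from compound 2 in a single place: ((4-methylphenyl)sulfonyl)amino in place of propyl on a saturated chain carbon bound to an aromatic carbon. For the measured compounds named here, no pair of measured compounds differing in one place is available, so the size of this change has no precedent here. The step expected in this assay is a 1.1-fold lower number from compound 2 to compound 4 (0.02 log units; within the scatter), which is no more than the scatter of the assay. Compound 4 is accordingly estimated at 45000 nM, within a range from 12000 nM to 160000 nM, with a fair chance that only a limit is reported.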

Compound 4, half-maximal inhibitory concentration: 45800 nM
Beside the measured number, compound 4's estimate is 1.0-fold (0.01 log units) below it; the measured number falls inside the stated range.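

In this assay, among the compounds shown here, the first step that can be read at this position is a 1.0-fold lower number from compound 2 to compound 4 (0.02 log units; within the scatter). The place on a saturated chain carbon bound to an aromatic carbon therefore takes ((4-methylphenyl)sulfonyl)amino in place of propyl, gaining a six-membered aromatic ring, a hydrogen-bond donor and two hydrogen-bond acceptors, while the two numbers remain within the scatter of each other. Compound 1 and compound 3 each remain a limit of the assay rather than a number: the limit of > 100000 nM in this assay, at which 2 of the 4 values shown sit.

As far as these compounds go, whether an amine, a carboxylic acid or a longer chain at this position would set a compound apart from compound 2 remains open. Any steps involving compound 1 or compound 3 cannot be read.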